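Diisopropylcarbamoyl on the shared core: working notes

The source may hold more compounds than are shown below. What is called first, only, known or untested is meant among the compounds shown, and "the series" means these compounds.

Measured so far in a functional assay on HL-60 cells (Homo sapiens) for antiproliferative activity, read by MTT assay, with a stated time of 48 h; a higher number here means a weaker inhibitor, a lower number a stronger inhibitor:
- compound 1 `COC/C1=C/C[C@](C)(CCC=C(C)C)/C=C/[C@@H](OC(=O)C=C(C)C)[C@](C)(O)/C=C/C1=O` gives 3070 nM
- compound 2 `CCN(CC)C/C1=C/C[C@](C)(CCC=C(C)C)/C=C/[C@@H](OC(=O)C=C(C)C)[C@](C)(O)/C=C/C1=O` gives 140 nM
- compound 3 `CO/N=C/C1=C/C[C@](C)(CCC=C(C)C)/C=C/[C@@H](OC(=O)C=C(C)C)[C@](C)(O)/C=C/C1=O` gives 4760 nM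

Compound 3 at 4760 nM is not separated from the methoxy analogue (a 1.6-fold higher number from compound 1 to compound 3 (0.19 log units; within the scatter)) and stands far from the diethylamino analogue (a 34-fold higher number from compound 2 to compound 3 (1.53 log units; beyond the scatter)). Compound 4 `CC(C)=CCC[C@]1(C)/C=C/[C@@H](OC(=O)C=C(C)C)[C@](C)(O)/C=C/C(=O)/C(C(=O)N(C(C)C)C(C)C)=C\C1` carries diisopropylcarbamoyl in place of the group of compound 3 on a double-bonded ring carbon (a group of 9 heavy atoms (7 carbon, 1 nitrogen, 1 oxygen; no ring) in place of a group of 4 heavy atoms (2 carbon, 1 nitrogen, 1 oxygen; no ring), on a double-bonded ring carbon).

The only large drop in the series came with diethylamino in place of methoxy (a 22-fold lower number from compound 1 to compound 2 (1.34 log units; beyond the scatter)). Compound 4 has no diethylamino group, and its nitrogen sits in a carbamoyl group, so that drop is expected to carry over poorly. The nearer guide is the change at this ring carbon that left the number within the scatter (a 1.6-fold higher number from compound 1 to compound 3 (0.19 log units; within the scatter)). Going by the values given here, no carbamoyl compound has been measured yet, so the uncertainty is wide. In this assay the estimated step (a 1.6-fold lower number from compound 3 to compound 4 (0.20 log units; within the scatter)) is expected to stay within the scatter. Compound 4 is estimated at 3000 nM with an expected range (700 nM to 9000 nM) in this assay for now.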

Compound 4, half-maximal inhibitory concentration: 12700 nM
Estimate against measurement, compound 4: 4.2-fold (0.63 log units) below; measured number above the stated range.
By their numbers in this assay, from the lowest: compound 2; then compounds 1 and 3 (each within the scatter of the next); then compound 4.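

In this assay, the number at this double-bonded ring carbon now moves upward beyond the scatter with a group other than the earlier oxygen-bearing ones: a 2.7-fold higher number from compound 3 to compound 4 (0.43 log units; beyond the scatter) and a 4.1-fold higher number from compound 1 to compound 4 (0.62 log units; beyond the scatter), so the position does not leave the number unchanged for every non-amine replacement. The spread at this one carbon also widens, with a 91-fold higher number from compound 2 to compound 4 (1.96 log units; beyond the scatter), and compound 4 now stands beyond the scatter of all three earlier compounds, as the weakest of the four. Nothing at hand gives a reason for the rise.

The compounds shown leave open whether the rise goes with the carbonyl attached to this carbon or with the two isopropyl groups on the nitrogen; dimethylcarbamoyl or a carboxylic acid here would separate the two. On these data alone, it is also open whether (diisopropylamino)methyl would stay near compound 2 at 140 nM.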